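The compounds below may be only part of what the source reports. "The series", "measured", "known", "first", "only" and "open" are said of these compounds alone.

Measured so far:
Compound 1 `CCOc1ccc(Br)cc1-c1cc(Nc2ccc(C#N)cc2)nc(N)n1`: 70 nM
Compound 2 `Cc1ccc(Br)cc1-c1cc(Nc2ccc(Cl)cc2)nc(N)n1`: 70 nM

In a functional assay on K562 cells (Homo sapiens) for inhibition (on this read-out higher numbers stand for weaker inhibition and lower numbers for stronger inhibition), compound 1 gives 70 nM and compound 2 gives 70 nM. The two values are level at the digits shown, so compound 1 stands with compound 2 within the scatter, and neither can be ranked above the other.

The next compound to be read is compound 3 `CCOc1ccc(Br)cc1-c1cc(Nc2ccccc2)nc(N)n1`. It keeps the core of compound 1 and changes in one place: hydrogen in place of cyano on an aromatic carbon. In words, hydrogen takes the place of cyano on an aromatic carbon, para to a large group, so 4-cyanophenyl becomes phenyl.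

The measured compounds offer no single-place step, so the effect of removing the cyano group has not been shown directly. The expectation rests on the structural change alone and carries wide uncertainty. A modest move towards weaker inhibition in this assay is expected, though a result within the scatter would not be surprising. The expected change is a 2.1-fold higher number from compound 1 to compound 3 (0.33 log units; beyond the scatter). For compound 3 the estimated value is 150 nM, with an expected range of 50 nM to 500 nM.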

Compound 3, half-maximal inhibitory concentration: 260 nM
The estimate for compound 3 lay 1.7-fold (0.24 log units) below the measured number, and the stated range covers the measured number.
By their numbers in this assay, from the lowest: compounds 1 and 2 (each within the scatter of the next); then compound 3.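

The step from 4-cyanophenyl to phenyl gives the series its first single-place reading in this assay and amounts to a 3.7-fold higher number from compound 1 to compound 3 (0.57 log units; beyond the scatter) on the core of compound 1. The cyano group on this aromatic carbon, para to a large group, therefore carries a real but modest part of the inhibition read here, as the step lies beyond the scatter without being large. Inhibition does not vanish with the cyano group gone, since in this assay compound 3 still gives 260 nM with only hydrogen at this place.

Nothing in hand bears on why the number moves with this change.

Compound 2 differs from compound 1 in more than one place, so its chlorine cannot be set directly against the cyano group or against hydrogen on the same core. Also open, from the compounds shown here alone, is how an amine, a carboxylic acid or a methoxy group at this same place would read against the cyano group and hydrogen, and whether the step keeps its size when the ethoxy group of compound 1 is replaced by another chain.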